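The source may hold more compounds than are shown below. What is called first, only, known or untested is meant among the compounds shown, and "the series" means these compounds.

Compound 3 `Cc1cccc(CN(C)CCCCn2c(=O)oc3ccccc32)c1` is the starting point. Within the data shown here, in an assay on membranes from liver for displacement of a labelled ligand from Sigma non-opioid intracellular receptor 1 (Rattus norvegicus), read by scintillation counting (on this read-out lower numbers stand for stronger inhibition and higher numbers for weaker inhibition), compound 3 gives 102 nM, the lowest number among the three compounds measured so far; in the same assay compound 1 `Cc1ccc(CN(C)CCCn2c(=O)oc3ccccc32)cc1` gives 871 nM and compound 2 `CN(CCCn1c(=O)oc2ccccc21)Cc1ccc(Cl)cc1` gives 1150 nM, both higher by more than the usual scatter. Among the measured compounds shown here, no single-change step links either of them to compound 3, so they only mark where compound 3 stands. For the measured compounds named here, the one measured step that does exist, a 1.3-fold higher number from compound 1 to compound 2 (0.12 log units; within the scatter), swaps one group on the aromatic ring for another and hardly moves the number.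

Compound 4 `Cc1ccc(CN(C)CCCCn2c(=O)oc3ccccc32)c(C)c1` differs from compound 3 in one place: 2,4-dimethylphenyl in place of 3-methylphenyl on a saturated chain carbon bound to an amine nitrogen. This again touches only the substitution of that aromatic ring, the kind of change that in the step from compound 1 to compound 2 stayed within the scatter, while the chain and the core are kept. The expected step, a 1.5-fold higher number from compound 3 to compound 4 (0.17 log units; within the scatter), is therefore small, with no clear direction. For compound 4 the expected value in this assay is 150 nM, estimated to lie between 50 nM and 450 nM.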

Compound 4, inhibition constant: 239 nM
The estimate for compound 4 lay 1.6-fold (0.20 log units) below the measured number; the range from low to high includes it.
By their numbers in this assay, from the lowest: compound 3; then compound 4; then compounds 1 and 2 (each within the scatter of the next).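

In this assay, moving to the 2,4-dimethylphenyl group gives a 2.3-fold higher number from compound 3 to compound 4 (0.37 log units; beyond the scatter), so a change in the substitution of this aromatic ring can shift the number by more than the scatter, which the earlier chloro-for-methyl swap did not do. The shift is modest, and the entering group differs in two ways: it has 8 heavy atoms instead of 7, and its methyl groups are placed differently, so this one step cannot show which of these matters. Nothing measured here explains the change in binding.

Still open, from the compounds shown here alone, is how a plain phenyl group or a 4-methoxyphenyl group would compare on the chain of compound 3 . Also open, going by these compounds, is what a longer chain would do with the 3-methylphenyl group kept in place.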